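Nitro to amino on the anilino arm: lipophilicity notes

A few compounds are considered here, and "the series" means these few. Any claim that something is new, unique, unknown or untested is made for them only; others in the source may bear on it.

Compound 1 `CCOC(=O)C1=C(C)NC(=S)NC1c1cn(C(=O)CNc2ccc([N+](=O)[O-])c(Cl)c2)c2ccccc12`, compound 2 `CCOC(=O)C1=C(C)NC(=S)NC1c1cn(C(=O)CNc2ccccc2[N+](=O)[O-])c2ccccc12` and compound 3 `CCOC(=O)C1=C(C)NC(=S)NC1c1cn(C(=O)CNc2cccc([N+](=O)[O-])c2)c2ccccc12` share one core and differ only in the aryl group on the amine nitrogen. In a physicochemical assay for lipophilicity (on this read-out higher numbers stand for higher lipophilicity and lower numbers for lower lipophilicity), compound 1 gives 3.4, compound 2 gives 2.88 and compound 3 gives 2.88. Compound 3 stands level with compound 2, the two together being the lowest of the three numbers; compound 1 sits higher, as a number 0.52 log units lower from compound 1 to compound 3 (beyond the scatter) shows, and likewise a number 0.52 log units lower from compound 1 to compound 2 (beyond the scatter). Exchanging 2-nitrophenyl for 3-nitrophenyl gave no change at the digits printed from compound 2 to compound 3 (within the scatter).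

Compound 4 `CCOC(=O)C1=C(C)NC(=S)NC1c1cn(C(=O)CNc2ccccc2N)c2ccccc12` is not yet measured. Its difference from compound 3: 2-aminophenyl in place of 3-nitrophenyl on an amine nitrogen. Within the data shown here, no measured step exchanges a nitro group for an amino group. The measured steps bear on it only in showing that the aryl group on this nitrogen shifts the read-out in this assay by modest amounts, while no change at the digits printed from compound 2 to compound 3 (within the scatter) shows none. For compound 4 a step downward in this assay is expected, a number 0.88 log units lower from compound 3 to compound 4 (beyond the scatter), larger than any measured step here. Compound 4 is estimated at 2, in the range 1.5 to 2.5.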

Compound 4, partition coefficient: 2.14
Compound 4: the middle estimate sits 0.14 log units below what was measured; measured number inside the range.
By their numbers in this assay, from the lowest: compound 4; then compounds 2 and 3 (each within the scatter of the next); then compound 1.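

Amino in place of nitro on an aromatic carbon gives a number 0.74 log units lower from compound 2 to compound 4 (beyond the scatter), the first step in this assay that exchanges the nitro group itself rather than its placement or the chlorine alongside it. Across the same amine nitrogen, 2-aminophenyl in place of 3-nitrophenyl gives a number 0.74 log units lower from compound 3 to compound 4 (beyond the scatter), so the read-out that stayed level between the two nitrophenyl compounds does move once nitro gives way to amino. With 2-aminophenyl in place of 3-chloro-4-nitrophenyl, the series now spans a number 1.26 log units lower from compound 1 to compound 4 (beyond the scatter), and nothing measured here accounts for the size of these steps.

On these data alone, whether 3-aminophenyl would stand level with 2-aminophenyl, as the two nitrophenyl groups do, remains open. Also open, as far as these compounds go, is where a methoxy group or a carboxylic acid would fall in place of the amino group.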